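The source may hold more compounds than are shown below. What is called first, only, known or untested is meant among the compounds shown, and "the series" means these compounds.

Working notes on the series. Compound 1 `N#Cc1c(Nc2ccccc2Cl)nc(SCc2cn(Cc3ccccc3Cl)nn2)nc1-c1ccccc1` and compound 2 `Cc1ccccc1Nc1nc(SCc2cn(Cc3ccccc3Cl)nn2)nc(-c2ccccc2)c1C#N` share one core; compound 3 `N#Cc1c(Nc2ccccc2F)nc(SCc2cn(Cc3ccc(Cl)cc3)nn2)nc1-c1ccccc1` and compound 4 `Cc1ccc(Cn2cc(CSc3nc(Nc4ccccc4F)c(C#N)c(-c4ccccc4)n3)nn2)cc1` share another, and the difference between the two cores is not broken down here.

In a functional assay on B16-F10 cells (Mus musculus) for inhibition, read by MTT assay, with a stated time of 72 h (on this read-out higher numbers stand for weaker inhibition and lower numbers for stronger inhibition), compound 1 gives 8350 nM. In this assay compound 2 gives 2760 nM. The change between them, (methyl in place of chloro on an aromatic carbon), made a step of a 3.0-fold lower number from compound 1 to compound 2 (0.48 log units; beyond the scatter).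

For compound 3, this assay returns only a limit, > 64000 nM; this is the limit of > 64000 nM in this assay, at which 1 of the 3 values shown sits, and not a number.

Compound 4 carries the same kind of change as the measured pair, (methyl in place of chloro on an aromatic carbon), but not the same one: in the measured pair the methyl stands ortho to a large group, here it stands para to a large group. The starting point of the new step is known only as the limit (the limit of > 64000 nM in this assay, at which 1 of the 3 values shown sits), so where the parent truly lies is open.

Within the data shown here, the step expected here is an at least 1.6-fold lower number from compound 3 to compound 4 (0.20 log units; that floor lies within the scatter), set beside the measured step of a 3.0-fold lower number from compound 1 to compound 2 (0.48 log units; beyond the scatter) as its only guide. Compound 4 is therefore expected near 40000 nM, with a range from 12000 nM to 150000 nM, and with a real chance that this assay again reports only a limit for compound 4 rather than a number.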

Compound 4, half-maximal inhibitory concentration: 16000 nM
Compound 4: the middle estimate sits 2.5-fold (0.40 log units) above what was measured; measured number inside the range.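

In this assay, methyl in place of chloro on an aromatic carbon, here read as 4-chlorobenzyl to 4-methylbenzyl with the new group para to a large group, gives an at least 4.0-fold lower number from compound 3 to compound 4 (0.60 log units; beyond the scatter), which runs in the same direction as the step on the core of compound 1 and, like it, lies beyond the scatter. The direction of the change therefore carries over between the two cores shown, but whether the size carries over remains unsettled: the same change on two cores in this assay, a 3.0-fold lower number (0.48 log units; beyond the scatter) from compound 1 to compound 2 and an at least 4.0-fold lower number (0.60 log units; beyond the scatter) from compound 3 to compound 4; the limit leaves it open whether they differ. On these data alone, compound 3 stands only as a limit and not as a number, so the full size of its step is unknown, and two pairs on two cores establish no general rule for the series: the limit of > 64000 nM in this assay, at which 1 of the 4 values shown sits.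

The compounds shown leave open how other groups would behave at the place held by the methyl in compound 4, for example a methoxy, an amine or a carboxylic acid on the 4-methylphenyl ring. They also leave open whether the same change would give a step in the same direction on any further core, and how much of the gap between compound 2 and compound 4 belongs to their other structural differences.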